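Compound 2 to compound 3: working notes

The source may report more compounds than this note shows. Statements on the series, on what has been measured and on what is new or still open speak of the compounds shown alone.

- Compound 1 `CN(C)C(=O)c1ncc([N+](=O)[O-])n1C`: > 100000 nM, a limit
- Compound 2 `CN(C)C(=O)c1ncc([N+](=O)[O-])[nH]1`: > 100000 nM, a limit

Both entries come from a toxicity assay on HEK293 cells (Homo sapiens) for inhibition, read by resazurin assay, with a stated time of 24 h; on this read-out higher numbers stand for lower toxicity in this test and lower numbers for higher toxicity in this test. Compound 2 stands only at a limit, > 100000 nM, and gives no number to move from. Among the measured compounds shown here, the series so far shows (the limit of > 100000 nM in this assay, at which 2 of the 2 values shown sit).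

Compound 3 `O=C(NCCO)c1ncc([N+](=O)[O-])[nH]1` differs from compound 2 by (2-hydroxyethyl)amino in place of dimethylamino on a carbonyl carbon, with (2-hydroxyethyl)amino in place of dimethylamino on a carbonyl carbon.

For the measured compounds named here, the one measured step, a step that the two limits leave unreadable from compound 1 to compound 2, changes an aromatic nitrogen rather than this carbonyl carbon, and it offers no size to carry over. No step beyond the scatter is therefore expected in this assay, in either direction, and the estimated step is a step that the limit leaves unreadable from compound 2 to compound 3. For compound 3 the estimate is 120000 nM, expected between 50000 nM and 300000 nM, and a report as a limit is the likeliest outcome.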

Compound 3, half-maximal cytotoxic concentration: > 100000 nM
Compound 3: no number, only a limit; the forecaster's own chance of this, stated with the estimate: 90%; the middle value does not contradict the limit.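

Compound 3 stands at > 100000 nM in this assay, a limit, and no step can be read between compound 2 and compound 3. The compounds shown leave open whether any change on the shared core would give a measurable value, as the series still rests on one reading: the limit of > 100000 nM in this assay, at which 3 of the 3 values shown sit.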